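From Methoxy to Methoxycarbonyl on the Shared Core

The source may hold more compounds than are shown below. What is called first, only, known or untested is meant among the compounds shown, and "the series" means these compounds.

Compound 1 `CCOC(=O)c1ccc(CO/N=C/c2c(C)nn(C)c2Oc2ccc(Cl)cc2)cc1` gives 20.9% in a functional assay on MKN-45 cells (Homo sapiens) for antiproliferative activity, tested at 1 uM; on this read-out higher numbers stand for more inhibition at the one concentration tested (going by the name of the read-out) and lower numbers for less inhibition.
Compound 2 `Cc1nn(C)c(Oc2ccccc2)c1/C=N/OCc1cccc(-c2ccccc2)c1C` gives -12.1% in this assay.
Compound 3 `COc1ccc(CO/N=C/c2c(C)nn(C)c2Oc2ccc(Cl)cc2)cc1` gives 28.1% in this assay.

Compound 3 holds the highest of the three numbers, but its gap to compound 1 lies within the scatter, so the two cannot be told apart; only compound 2 sits clearly lower, beyond the scatter.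

Compound 4 `COC(=O)c1ccc(CO/N=C/c2c(C)nn(C)c2Oc2ccc(Cl)cc2)cc1` differs from compound 3 in a single place: methoxycarbonyl in place of methoxy on an aromatic carbon. Going by the values given here, the one measured step that bears on this change is the move between compound 1 and compound 3, where an ethoxycarbonyl gave way to a methoxy: a number 7.2 percentage points higher from compound 1 to compound 3 (within the scatter). Going the other way, from methoxy to an ester, therefore costs little, and methoxycarbonyl is a shorter version of the ethoxycarbonyl seen in compound 1. A small downward step, within the scatter, is therefore expected, namely a number 5.1 percentage points lower from compound 3 to compound 4 (within the scatter). Compound 4 is estimated to give about 23% in this assay, with a likely range from 10% to 36%.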

Compound 4, a percentage reported as inhibition, at one concentration (the size of the read-out at that concentration, not a potency): 26.1%
Compound 4: middle estimate off by 3.1 percentage points, on the low side; measured number inside the range.
By their numbers in this assay, from the lowest: compound 2; then compounds 1, 4 and 3 (each within the scatter of the next).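

In this assay, this place on the aromatic ring, para to a large group, has now carried methoxy, methoxycarbonyl and ethoxycarbonyl, and the numbers do not separate them: the swap to methoxycarbonyl gives a number 2 percentage points lower from compound 3 to compound 4 (within the scatter) and the shortening of the ester gives a number 5.2 percentage points higher from compound 1 to compound 4 (within the scatter) in the same read-out. Compound 4 thus shows that neither adding a carbonyl to the methoxy nor removing the terminal methyl of the ester moves the number beyond the scatter, so compounds 1, 3 and 4 form one group with no order among them. No measurement here accounts for why these groups give such similar numbers.

Still open, going by these compounds, is whether a different kind of group at this place, such as a carboxylic acid or an amine, would stand apart from these three. A longer chain on the ester, such as butoxycarbonyl, also remains an open case.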